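The source may hold more compounds than are shown below. What is called first, only, known or untested is meant among the compounds shown, and "the series" means these compounds.

Measured so far in an assay on HEK293 cells for agonist activity at Toll-like receptor 8 (Homo sapiens), read by a luciferase reporter, with a stated time of 6 h; on this read-out higher numbers stand for an effect only at larger amounts of compound and lower numbers for an effect already at smaller amounts: compound 1 `CCCCNc1nc(N)nc2c1CN(Cc1cccnc1)CC2` gives 0.13 uM. Compound 2 `CCCCNc1nc(N)nc2c1CN(C(=O)c1ccncc1)CC2` gives only a limit of the assay, > 25 uM. Compound 3 `CCCCNc1nc(N)nc2c1CN(C(=O)c1cnc(C)cn1)CC2` gives 6.8 uM.

Of the numbers shown, compound 3 carries the highest; its nearest neighbour is compound 1, with a lower number beyond the scatter, while compound 2 stands at a limit (the limit of > 25 uM in this assay, at which 1 of the 3 values shown sits). Compound 4 `CCCCNc1nc(N)nc2c1CN(C(=O)c1scnc1C)CC2` differs from compound 3 by 4-methyl-1,3-thiazol-5-yl in place of 5-methylpyrazin-2-yl on a carbonyl carbon. Going by the values given here, two measured steps bear on it: an at least 190-fold higher number from compound 1 to compound 2 (2.28 log units; beyond the scatter) and an at least 3.6-fold lower number from compound 2 to compound 3 (0.56 log units; beyond the scatter). Both touch the group on the carbonyl carbon, and the second shows that exchanging one aryl ring for another there moves the number at least modestly. An exchange of a six-membered aromatic ring for a five-membered one on the same carbonyl is expected to shift the number little, a 1.0-fold higher number from compound 3 to compound 4 (0.01 log units; within the scatter). Compound 4 is thus estimated at 7 uM, between 2 uM and 25 uM.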

Compound 4, minimum effective concentration: 5.6 uM
Beside the measured number, compound 4's estimate is 1.3-fold (0.10 log units) above it, and the stated range covers the measured number.
By their numbers in this assay, from the lowest: compound 1; then compounds 4 and 3 (each within the scatter of the next). At a limit, above all of these: compound 2.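

On the carbonyl carbon, the five-membered 4-methyl-1,3-thiazol-5-yl ring and the six-membered 5-methylpyrazin-2-yl ring cannot be told apart, with a 1.2-fold lower number from compound 3 to compound 4 (0.08 log units; within the scatter). The 4-methyl-1,3-thiazol-5-yl group in place of pyridin-4-yl gives an at least 4.4-fold lower number from compound 2 to compound 4 (0.64 log units; beyond the scatter), and compound 2 stands at a limit of the assay: the limit of > 25 uM in this assay, at which 1 of the 4 values shown sits. Even so, the carbonyl-linked 4-methyl-1,3-thiazol-5-yl group leaves a wide gap to the (pyridin-3-yl)methyl group, with a 43-fold higher number from compound 1 to compound 4 (1.63 log units; beyond the scatter).

Going by these compounds, whether that gap belongs to the carbonyl or to the ring remains open. A (4-methyl-1,3-thiazol-5-yl)methyl group on the same amine nitrogen in a ring would separate the two.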